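Dropping the Methoxy from the Hydroxy-Methoxyphenyl Analogue

A few compounds are considered here, and "the series" means these few. Any claim that something is new, unique, unknown or untested is made for them only; others in the source may bear on it.

Measured so far in a functional assay on HT-29 cells (Homo sapiens) for cytotoxicity, read by MTT assay, with a stated time of 72 h; a lower number here means a stronger inhibitor, a higher number a weaker inhibitor:
compound 1 `CN(C)CCn1cnnc1-c1cc(Oc2ccc(NC(=O)N/N=C/c3ccccc3)cc2F)ccn1` gives 1120 nM
compound 2 `COc1cc(/C=N/NC(=O)Nc2ccc(Oc3ccnc(-c4nncn4CCN(C)C)c3)c(F)c2)cc(OC)c1OC` gives 3620 nM
compound 3 `COc1ccc(/C=N/NC(=O)Nc2ccc(Oc3ccnc(-c4nncn4CCN(C)C)c3)c(F)c2)cc1O` gives 960 nM

All three share one core and differ only in the aryl group on the carbon with a double bond to nitrogen. Compound 3 and compound 1 sit together: the step of a 1.2-fold lower number from compound 1 to compound 3 (0.07 log units; within the scatter) cannot be separated from repeat-to-repeat noise. Compound 2 sits apart, as the step of a 3.8-fold lower number from compound 2 to compound 3 (0.58 log units; beyond the scatter) shows, and likewise a 3.2-fold higher number from compound 1 to compound 2 (0.51 log units; beyond the scatter).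

Compound 4 `CN(C)CCn1cnnc1-c1cc(Oc2ccc(NC(=O)N/N=C/c3cccc(O)c3)cc2F)ccn1` is compound 3 with one change: hydrogen in place of methoxy on an aromatic carbon. The measured steps speak only indirectly to this. Adding both a hydroxy and a methoxy onto the plain phenyl of compound 1 changed little, while adding three methoxy groups gave the modest worsening seen in compound 2. Taking one methoxy away from compound 3 therefore seems unlikely to move the number far in either direction; a step within the scatter is the expectation, with a slight lean toward a smaller loss rather than a gain.

Compound 4 is thus expected to give about 1100 nM in this assay, with a plausible range from 450 nM to 2700 nM, an expected step of a 1.1-fold higher number from compound 3 to compound 4 (0.06 log units; within the scatter).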

Compound 4, half-maximal inhibitory concentration: 330 nM
For compound 4 the middle estimate is 3.3-fold (0.52 log units) above the measured one, outside the stated range (below it).
By their numbers in this assay, from the lowest: compound 4; then compounds 3 and 1 (each within the scatter of the next); then compound 2.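

Removing the methoxy from the ring of compound 3 proves to matter in this assay: a 2.9-fold lower number from compound 3 to compound 4 (0.46 log units; beyond the scatter) is a modest step beyond the scatter, making compound 4 the strongest of the four. The same hydroxy group also behaves differently depending on its neighbour, since a 3.4-fold lower number from compound 1 to compound 4 (0.53 log units; beyond the scatter) shows a gain beyond the scatter for hydroxy alone, whereas a 1.2-fold lower number from compound 1 to compound 3 (0.07 log units; within the scatter) stays within the scatter when a methoxy sits ortho to that hydroxy. Among these aryl groups the choice can shift the number considerably, with an 11-fold lower number from compound 2 to compound 4 (1.04 log units; beyond the scatter) as the large step separating the 3,4,5-trimethoxyphenyl and 3-hydroxyphenyl compounds.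

No measurement of any other kind bears on this result, so the reason for these steps remains open. Also open, as far as these compounds go, is whether the hydroxy group itself is what counts on the 3-hydroxyphenyl ring, or whether an amine or a carboxylic acid in its place would give a similar number in this assay.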